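Two quinoline ethers and a benzyl variant in permeability

The source may hold more compounds than are shown below. What is called first, only, known or untested is meant among the compounds shown, and "the series" means these compounds.

The study measured two compounds in an ADME assay for permeability, using PAMPA, with a stated time of 30 min, at pH 7.4; a lower number here means that the compound crosses the layer more slowly, a higher number that the compound crosses the layer faster. Compound 1 `COc1cccc(Oc2ccc3c(NCCCNCc4cc(F)ccc4OC)ccnc3c2)c1` gives 317 10^-6 cm/s in this assay. Compound 2 `COc1cccc(CNCCCNc2ccnc3cc(-c4ccc(C(F)(F)F)cc4)ccc23)c1O` gives 237 10^-6 cm/s in this assay. Compound 2 stands alongside compound 1: the two numbers lie within the usual scatter of each other, so no order between them can be read from the data.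

Compound 3 `COc1cccc(CNCCCNc2ccnc3cc(Cc4cccc(C(F)(F)F)c4)ccc23)c1O` has not yet been measured. It differs from compound 2 by one change, (3-(trifluoromethyl)benzyl in place of 4-(trifluoromethyl)phenyl on an aromatic carbon), on an aromatic carbon of the shared core, meta to a fused ring and para to a fused ring. Among the compounds with values here, no step between measured compounds that differ in one place is available, so the expectation rests on the values of compound 1 and compound 2 alone.

Compound 3 is expected to give about 230 10^-6 cm/s in this assay, with an estimated range from 120 10^-6 cm/s to 420 10^-6 cm/s. The step this estimate implies, a 1.0-fold lower number from compound 2 to compound 3 (0.01 log units; within the scatter), is expected to stay within the scatter, in no clear direction.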

Compound 3, apparent permeability: 23 10^-6 cm/s
Compound 3: the middle estimate sits 10-fold (1.00 log units) above what was measured; measured number below the stated range.
By their numbers in this assay, from the lowest: compound 3; then compounds 2 and 1 (each within the scatter of the next).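

At this aromatic carbon, meta to a fused ring and para to a fused ring, the read-out of this assay proves sensitive to the group attached: 3-(trifluoromethyl)benzyl in place of 4-(trifluoromethyl)phenyl gives a 10-fold lower number from compound 2 to compound 3 (1.01 log units; beyond the scatter). Compounds 1 and 2 could not show this, as they differ in more than one place. The step is large although the two groups have the same ring type and the same counts of hydrogen-bond donors and acceptors, differing by a single carbon, and nothing measured here accounts for it.

The compounds shown leave open whether the step follows the added carbon or the shift of the trifluoromethyl group. A 3-(trifluoromethyl)phenyl or a 4-(trifluoromethyl)benzyl group on this carbon would separate the two.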